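The compounds below may be only part of what the source reports. "The series", "measured", "known", "first", "only" and "open" are said of these compounds alone.

Working notes on the series. Compound 3 `O=C(/C=C\c1cccc(Cl)c1)N1N=C(c2ccncc2)OC1c1c[nH]c2ccccc12` gives only a limit in an ADME assay on HeLa cells (Homo sapiens) for cytotoxicity, read by MTT assay, with a stated time of 72 h (on this read-out higher numbers stand for weaker inhibition of growth and lower numbers for stronger inhibition of growth), > 30 ug/mL. Compound 1 `O=C(/C=C\c1ccccc1)N1N=C(c2ccncc2)OC1c1c[nH]c2ccccc12` likewise gives only a limit in this assay, > 30 ug/mL. Compound 2 `Cc1ccc(/C=C\C(=O)N2N=C(c3ccncc3)OC2c2c[nH]c3ccccc23)cc1` also gives only a limit in this assay, > 30 ug/mL. All three measured compounds thus sit at the limit of > 30 ug/mL in this assay, at which 3 of the 3 values shown sit, and none of the steps among them can be sized: a step that the two limits leave unreadable from compound 1 to compound 2, a step that the two limits leave unreadable from compound 1 to compound 3, and a step that the two limits leave unreadable from compound 2 to compound 3.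

Compound 4 `O=C(/C=C\c1ccc(Cl)cc1)N1N=C(c2ccncc2)OC1c1c[nH]c2ccccc12` has not yet been measured in this assay. It differs from compound 3 by 4-chlorophenyl in place of 3-chlorophenyl on a double-bonded chain carbon bound to a double-bonded chain carbon. The measured step that most resembles it is the swap of the aryl group on the same chain carbon from compound 2 to compound 3, which is unreadable because both ends sit at the limit of > 30 ug/mL in this assay, at which 3 of the 3 values shown sit; the methyl and chloro additions onto the aryl ring of compound 1 are unreadable for the same reason. Nothing in this set has moved a value off the limit, so the step that the limit leaves unreadable from compound 3 to compound 4 is expected to be no larger than the scatter, with no readable direction. Compound 4 is accordingly estimated at 50 ug/mL, in the range 25 ug/mL to 150 ug/mL, and is expected most likely to be reported again only as a limit.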

Compound 4, concentration for 50% growth inhibition: > 30 ug/mL
Compound 4 ended at the assay's limit; the forecaster's own chance of this, stated with the estimate: 85%; the middle value does not contradict the limit.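

The steps to compound 4 from compound 1, compound 2 and compound 3 cannot be read in this assay, because both ends of each step are limits: the limit of > 30 ug/mL in this assay, at which 4 of the 4 values shown sit.

The compounds shown leave open whether the 3-chlorophenyl and 4-chlorophenyl groups, or the chloro and methyl substituents, differ at all in this assay, and in which direction.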